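The compounds below may be only part of what the source reports. "The series", "measured", "known", "first", "only" and "open" are said of these compounds alone.

Of the compounds shown here, three have so far been measured in an ADME assay on the whole organism (plasma) for pharmacokinetics, with Homo sapiens as the target; on this read-out lower numbers stand for a shorter-lived compound and higher numbers for a longer-lived compound. Compound 1 `CC[C@@H](C(=O)N[C@H](/C=C/C(=O)OCc1ccccc1)C[C@@H]1CCNC1=O)n1cccc(NC(=O)c2cc(C)on2)c1=O` gives 2.5 h, compound 2 `C#CC[C@@H](C(=O)N[C@H](/C=C/C(=O)OCc1ccccc1)C[C@@H]1CCNC1=O)n1cccc(NC(=O)c2cc(C)on2)c1=O` gives 4.3 h, and compound 3 `CC[C@@H](C(=O)N[C@H](/C=C/C(=O)OC1CCC1)C[C@@H]1CCNC1=O)n1cccc(NC(=O)c2cc(C)on2)c1=O` gives 9.2 h. Compound 2 thus stands second highest of the three: its value lies within the scatter of compound 1, while compound 3 sits beyond the scatter above it. Compound 4 `C#CC[C@@H](C(=O)N[C@H](/C=C/C(=O)OC1CCCC1)C[C@@H]1CCNC1=O)n1cccc(NC(=O)c2cc(C)on2)c1=O` differs from compound 2 by cyclopentyl in place of benzyl on an oxygen next to a carbonyl group. The step that bears on this change is the exchange of benzyl for cyclobutyl on an oxygen next to a carbonyl group, which gave a 3.7-fold higher number from compound 1 to compound 3 (0.57 log units; beyond the scatter). The other known step, a 1.7-fold higher number from compound 1 to compound 2 (0.24 log units; within the scatter), concerns a different place and offers no guidance here. A modest rise is therefore expected, a 2.8-fold higher number from compound 2 to compound 4 (0.45 log units; beyond the scatter). Compound 4 is accordingly estimated at 12 h, with a range from 5 h to 28 h.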

Compound 4, half-life: 12.5 h
For compound 4 the middle estimate is 1.0-fold (0.02 log units) below the measured one; the range from low to high includes it.
By their numbers in this assay, from the lowest: compounds 1 and 2 (each within the scatter of the next); then compounds 3 and 4 (each within the scatter of the next).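

In this assay, cyclopentyl in place of benzyl on an oxygen next to a carbonyl group gives a 2.9-fold higher number from compound 2 to compound 4 (0.46 log units; beyond the scatter), a step beyond the scatter. The earlier rise, a 3.7-fold higher number from compound 1 to compound 3 (0.57 log units; beyond the scatter), came with cyclobutyl on the compound carrying the shorter saturated chain, so the rise on leaving benzyl now appears with a second ring and in the ethynyl-bearing compounds too. No available evidence explains this rise. Still open, from the compounds shown here alone, is how this assay responds at this oxygen to cyclohexyl, or to a carboxylic acid in place of the ester.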